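A few compounds are considered here, and "the series" means these few. Any claim that something is new, unique, unknown or untested is made for them only; others in the source may bear on it.

Compounds measured in a functional assay on A-375 cells (Homo sapiens) for antiproliferative activity, read by trypan blue exclusion, with a stated time of 48 h, tested at 10 uM; on this read-out lower numbers stand for a stronger effect and higher numbers for a weaker effect at the one concentration tested:

Compound 1 `CCCCCCC#Cc1ccc(S(=O)(=O)Nc2cccc(-c3csc(NC(C)=O)n3)c2)cc1`: 5.8%
Compound 2 `CC(=O)Nc1nc(-c2cccc(NS(=O)(=O)c3ccc(Br)cc3)c2)cs1`: 25.6%
Compound 3 `CC(=O)Nc1nc(-c2cccc(NS(=O)(=O)c3ccc(C#CCO)cc3)c2)cs1`: 48.8%

Compound 1 stands lowest of the three numbers in this assay; its nearest neighbour is compound 2, and compound 3 lies furthest from it. The step of a number 19.8 percentage points higher from compound 1 to compound 2 (beyond the scatter) is modest, the step of a number 43 percentage points higher from compound 1 to compound 3 (beyond the scatter) is large, and between the other two a number 23.2 percentage points higher from compound 2 to compound 3 (beyond the scatter) is again modest.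

The compound not yet measured is compound 4 `CC(=O)Nc1nc(-c2cccc(NS(=O)(=O)c3ccc(C#C[Si](C)(C)C)cc3)c2)cs1`. It differs from compound 1 in this way: a group of 4 heavy atoms (3 carbon, 1 silicon; no ring) in place of a group of 6 heavy atoms (6 carbon; no ring), on a triple-bonded carbon.

Within the data shown here, two measured steps bear on this change, as both start from compound 1 and alter the same group. The step of a number 19.8 percentage points higher from compound 1 to compound 2 (beyond the scatter) removes the whole oct-1-yn-1-yl group; the step of a number 43 percentage points higher from compound 1 to compound 3 (beyond the scatter) keeps the triple bond but exchanges pentyl for hydroxy. Compound 4 keeps the triple bond and carries a smaller group of three carbon and one silicon in place of hexyl, with no donor or acceptor entering, so a modest rise in this assay is expected rather than a large one. The estimated step is a number 16.2 percentage points higher from compound 1 to compound 4 (beyond the scatter). Compound 4 is therefore expected to give about 22% in this assay, within a range from 8% to 45%.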

Compound 4, a percentage reported as activity, at one concentration (the size of the read-out at that concentration, not a potency): < 1%
Compound 4 gave a limit, no number (the forecaster's own chance of this, stated with the estimate: 0%); at least 21 percentage points between middle value and limit.
By their numbers in this assay, from the lowest: compound 1; then compound 2; then compound 3. At a limit, below all of these: compound 4.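

In this assay compound 4 reaches a limit of the assay and not a number: the limit of < 1% in this assay, at which 1 of the 4 values shown sits.

The silicon-bearing group in place of hexyl on the triple-bonded carbon gives a number at least 4.8 percentage points lower from compound 1 to compound 4 (that floor lies within the scatter), so the order of these two compounds stays unsettled, and a chain as long as hexyl is not required for a low number at this place. The gap to the other substituents is clearer, with a number at least 47.8 percentage points lower from compound 3 to compound 4 (beyond the scatter), and a number at least 24.6 percentage points lower from compound 2 to compound 4 (beyond the scatter).

Going by these compounds, what remains open is how a tert-butyl group on the triple-bonded carbon would compare, which would speak to the part played by the silicon atom. Also open, on these data alone, is whether an amine or a carboxylic acid at the end of a longer chain would hold the number this low.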